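The source may hold more compounds than are shown below. What is called first, only, known or untested is meant among the compounds shown, and "the series" means these compounds.

Measured compounds in a functional assay on cells (Homo sapiens) for cytotoxicity, read by MTT assay, with a stated time of 24 h; on this read-out lower numbers stand for stronger inhibition and higher numbers for weaker inhibition:
- compound 1, `CCCCCCCCCCCCCCNC(=O)[C@H](CO)/N=C/c1ccc(O)cc1`: 19300 nM
- compound 2, `CCCCCCCCCCCCCCNC(=O)[C@H](CO)NCc1ccccc1OC`: 100000 nM
- compound 3, `CCCCCCCCCCCCCCNC(=O)[C@H](CO)/N=C/c1ccccc1`: 7670 nM

Compound 3 gives the lowest number of the three in this assay. Its nearest neighbour is compound 1, and the step of a 2.5-fold lower number from compound 1 to compound 3 (0.40 log units; beyond the scatter) is a modest one. The step of a 13-fold lower number from compound 2 to compound 3 (1.12 log units; beyond the scatter) is the largest within the set, though that pair differs in more than the ring substituent. The step of a 5.2-fold higher number from compound 1 to compound 2 (0.71 log units; beyond the scatter) runs the other way and is modest.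

Compound 4, `CCCCCCCCCCCCCCNC(=O)[C@H](CO)/N=C/c1ccccc1C`, differs from compound 3 only by methyl in place of hydrogen on an aromatic carbon. Going by the values given here, none of the measured steps involves a methyl on the aromatic ring, so no direct precedent exists. Among the compounds with values here, the only step touching a single substituent on that ring is a 2.5-fold lower number from compound 1 to compound 3 (0.40 log units; beyond the scatter), where removing hydroxy gave a modest lowering. Within the data shown here, a methyl is a different kind of group from hydroxy, so that step cannot be carried over directly; it shows only that changes on this ring produce modest effects. A step of no more than the scatter is therefore expected for compound 4 in this assay, with no preferred direction: a 1.0-fold lower number from compound 3 to compound 4 (0.01 log units; within the scatter). The estimate for compound 4 is 7500 nM, with a range of 3000 nM to 19000 nM.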

Compound 4, half-maximal inhibitory concentration: 87700 nM
Beside the measured number, compound 4's estimate is 12-fold (1.07 log units) below it, and the stated range ends below it.
By their numbers in this assay, from the lowest: compound 3; then compound 1; then compounds 4 and 2 (each within the scatter of the next).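

In this assay, going by these compounds alone, an aromatic carbon ortho to a large group proves sensitive to a single added methyl: an 11-fold higher number from compound 3 to compound 4 (1.06 log units; beyond the scatter) is a large step, whereas the only earlier step confined to one ring substituent, a 2.5-fold lower number from compound 1 to compound 3 (0.40 log units; beyond the scatter), was modest. The cost of the 2-methylphenyl group also outweighs the difference between the rings of compound 1 and compound 3, since a 4.5-fold higher number from compound 1 to compound 4 (0.66 log units; beyond the scatter) leaves the 4-hydroxyphenyl compound with the lower number, while a 1.1-fold lower number from compound 2 to compound 4 (0.06 log units; within the scatter) lies within the scatter, so this one methyl removes the advantage compound 3 held over compound 2. No measurement bearing on the origin of the methyl step is available.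

On these data alone, it remains open whether this step is specific to methyl or would also appear with fluoro, chloro or methoxy on the same aromatic carbon, and whether a methyl on another ring carbon would give a comparable step. As far as these compounds go, it is also open whether the step would persist with a shorter alkyl chain on the amide nitrogen.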